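Trimming the chain amide on a shared core

The source may hold more compounds than are shown below. What is called first, only, known or untested is meant among the compounds shown, and "the series" means these compounds.

Compound 1, `C=CC(=O)NCCCc1ccc2ncn(-c3ccnc(N)n3)c2c1`: 501000 nM
Compound 2, `C=CC(=O)NCCCCc1ccc2ncn(-c3ccnc(N)n3)c2c1`: 501000 nM

In an assay on Sf9 cells for inhibition of mitogen-activated protein kinase kinase kinase 14 variant S549D (Homo sapiens), with a stated time of 30 min, in the presence of a further agent that is not named here (a higher number here means a weaker inhibitor, a lower number a stronger inhibitor), compound 2 stands level with compound 1 at the digits shown, the only measured neighbour it has. Among the compounds with values here, the single measured step, no change at the digits printed from compound 1 to compound 2 (within the scatter), altered the chain length and left the number unmoved within the scatter.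

Compound 3, `CC(=O)NCCCc1ccc2ncn(-c3ccnc(N)n3)c2c1`, differs from compound 2 by acetamido in place of ((vinylcarbonyl)amino)methyl on a saturated chain carbon, three bonds along the chain from an aromatic carbon. Within the data shown here, no measured step alters the amide itself, so nothing bears directly on this change; what is known is only that both measured compounds sit at the same weak level, and the step from compound 1 to compound 2 gave no movement. The expectation is therefore no shift beyond the scatter, which means an expected step of no change at the digits printed from compound 2 to compound 3 (within the scatter). Compound 3 is estimated at 501000 nM, with a range from 200000 nM to 1000000 nM.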

Compound 3, half-maximal inhibitory concentration: > 100000 nM
Compound 3: no number, only a limit (the forecaster's own chance of this, stated with the estimate: 35%); the middle value lies beyond the limit too.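

In this assay compound 3 gives > 100000 nM, which is a limit and not a number. The steps from compound 1 and from compound 2 to compound 3 therefore cannot be read. On these data alone, whether methyl in place of vinyl on a carbonyl carbon changes inhibition at all stays open.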